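A few compounds are considered here, and "the series" means these few. Any claim that something is new, unique, unknown or untested is made for them only; others in the source may bear on it.

Of the compounds shown here, two built on a shared core have been measured in an assay on isolated protein for inhibition of Dihydrofolate reductase (Homo sapiens), read by spectrophotometry, using NADPH, with stated times of 5 s and 6 min; a lower number here means a stronger inhibitor, a higher number a weaker inhibitor. Compound 1 `NC1=NC2(CCOCC2)N(OCCCOc2ccc(Cl)cc2Cl)C(N)=N1` gives 7.46 nM, and compound 2 `NC1=NC2(CCOCC2)N(OCCCOc2cc(Cl)c(Cl)cc2Cl)C(N)=N1` gives 36 nM. Compound 2 therefore has the higher of the two numbers, and the step of a 4.8-fold higher number from compound 1 to compound 2 (0.68 log units; beyond the scatter) describes what a single added chlorine did. The next compound, compound 3 `Cc1ccc(OCCCON2C(N)=NC(N)=NC23CCOCC3)cc1`, differs from compound 2 by 4-methylphenyl in place of 2,4,5-trichlorophenyl on an oxygen on a saturated carbon. Among the compounds with values here, only that one step bears on this change, and it went toward a higher number as chlorine was added; with the three chlorine atoms gone and a methyl group in their place, the number is expected to move back in the other direction, although the new group is not one already seen here, so the step of a 3.6-fold lower number from compound 2 to compound 3 (0.56 log units; beyond the scatter) is estimated with caution. Compound 3 is therefore expected to give about 10 nM, with a range from 3 nM to 40 nM.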

Compound 3, half-maximal inhibitory concentration: 56.8 nM
Compound 3: the middle estimate sits 5.7-fold (0.75 log units) below what was measured; the measured number lies above the stated range.
By their numbers in this assay, from the lowest: compound 1; then compounds 2 and 3 (each within the scatter of the next).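

Replacing the 2,4,5-trichlorophenyl with 4-methylphenyl gives no separable change in this assay (a 1.6-fold higher number from compound 2 to compound 3 (0.20 log units; within the scatter)), so losing the chlorines does not by itself bring the number back down. Against the 2,4-dichlorophenyl of compound 1, the same 4-methylphenyl group does stand apart (a 7.6-fold higher number from compound 1 to compound 3 (0.88 log units; beyond the scatter)), which shows that this position responds to the group placed there and that, among these three compounds, the 2,4-dichlorophenyl gives the lowest number. Nothing shown here accounts for these differences.

From the compounds shown here alone, whether the two chlorines matter together or singly remains open, as a ring with one chlorine would be needed to separate them. Going by these compounds, how an unsubstituted phenyl, a methoxy group on the ring, or a longer chain to the ring would behave also remains unknown.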